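A few compounds are considered here, and "the series" means these few. Any claim that something is new, unique, unknown or untested is made for them only; others in the source may bear on it.

Measured so far in a functional assay on HEK293 cells for agonist activity at D(4) dopamine receptor (Homo sapiens), read by FLIPR; on this read-out lower numbers stand for smaller maximal responses and higher numbers for larger maximal responses:

compound 1 `Cc1cccc(NC(=O)CN2CCC(c3ccccc3C#N)CC2)c1`: 71%
compound 2 `Cc1cccc(NC(=O)CN2CCC(c3cccc(O)c3)CC2)c1`: 66%
compound 3 `Cc1cccc(NC(=O)CN2CCC(c3cccc(C#N)n3)CC2)c1`: 42%

Compound 3 stands lowest of the three numbers. Compounds 1 and 2 lie within the scatter of each other (a number 5 percentage points lower from compound 1 to compound 2 (within the scatter)), whereas both steps into compound 3 go beyond it: a number 29 percentage points lower from compound 1 to compound 3 (beyond the scatter) and a number 24 percentage points lower from compound 2 to compound 3 (beyond the scatter). In each of those steps the group on the saturated ring carbon went from a six-membered aromatic ring of carbon only to 6-cyanopyridin-2-yl, and the response fell.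

Compound 4 `Cc1cccc(NC(=O)CN2CCC(c3ccccc3F)CC2)c1` is not yet measured. It differs from compound 3 as follows:
2-fluorophenyl in place of 6-cyanopyridin-2-yl on a saturated ring carbon

This change runs in the opposite sense to the two measured steps: 6-cyanopyridin-2-yl leaves and a six-membered aromatic ring of carbon only enters, as in compounds 1 and 2. The bearing steps are therefore a number 29 percentage points lower from compound 1 to compound 3 (beyond the scatter) and a number 24 percentage points lower from compound 2 to compound 3 (beyond the scatter) read backwards, and a rise of modest size, beyond the scatter, is expected, bringing compound 4 back near the level of compounds 1 and 2. The step expected is a number 24 percentage points higher from compound 3 to compound 4 (beyond the scatter). For compound 4 the estimate in this assay is 66%, with a range from 52% to 80%.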

Compound 4, largest response reached (reported as efficacy), in percent of the reference or control that the assay uses: 57%
Compound 4: the middle estimate sits 9 percentage points above what was measured; the range from low to high includes it.
By their numbers in this assay, from the lowest: compound 3; then compounds 4, 2 and 1 (each within the scatter of the next, the first and the last beyond it).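

In this assay, a carbon-only aromatic ring bearing fluoro recovers part of the response lost with 6-cyanopyridin-2-yl (a number 15 percentage points higher from compound 3 to compound 4 (beyond the scatter)), and it stays within the scatter of the 3-hydroxyphenyl group (a number 9 percentage points lower from compound 2 to compound 4 (within the scatter)). Fluoro in place of cyano on an aromatic carbon is a change on the phenyl ring itself, and it also moves the response beyond the scatter (a number 14 percentage points lower from compound 1 to compound 4 (beyond the scatter)), so the level depends on the group carried by the carbon-only ring as well as on the ring type. Nothing on hand accounts for any of these steps.

Still open, going by these compounds, is how chloro or methoxy would compare with fluoro and cyano on that aromatic carbon. A plain pyridin-2-yl group would show whether the low response of compound 3 goes with the ring nitrogen or with the nitrile.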